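The source may hold more compounds than are shown below. What is called first, only, known or untested is meant among the compounds shown, and "the series" means these compounds.

Working notes on the series. Compound 1 `CCOC(=O)C(=O)Nc1cccccc1=O` carries a single ((ethoxycarbonyl)carbonyl)amino group on its seven-membered aromatic ring of carbon only. In a functional assay on the whole organism (strain Sprague-Dawley CD) for inhibition, with Rattus norvegicus as the target, read by paw edema, at a dose of 100 mg/kg by the oral route (a lower number here means a weaker effect, a higher number a stronger effect of the compound at the dose given), compound 1 gives 91%, the highest of the three numbers in hand. Compound 2 `CCOC(=O)C(=O)Nc1c(C)ccccc1=O` gives 37% in this assay, and compound 3 `CCOC(=O)C(=O)Nc1ccccc(OC)c1=O` gives 56%. Both measured steps away from compound 1 run downward: a number 54 percentage points lower from compound 1 to compound 2 (beyond the scatter) and a number 35 percentage points lower from compound 1 to compound 3 (beyond the scatter). Each replaces hydrogen on an aromatic carbon of the shared core, and each is large.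

Compound 4 `CCOC(=O)C(=O)Nc1ccc(NC(=O)C(=O)OCC)c(=O)cc1` is the next step from compound 1. The change is ((ethoxycarbonyl)carbonyl)amino in place of hydrogen on an aromatic carbon; the group that enters is the one already present once, placed three ring bonds from the ring atom that bears the first. Among the measured compounds shown here, no measured step adds this group a second time, so the ring substitutions of compound 2 and compound 3 are the only guide. Both were large and downward, so a further substitution on the same ring is expected to lower the number as well, beyond the scatter, though the size is uncertain. For compound 4 the estimate in this assay is 45%, between 20% and 72%, an expected step of a number 46 percentage points lower from compound 1 to compound 4 (beyond the scatter).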

Compound 4, a percentage reported as inhibition, in the whole organism at one dose (the size of the read-out at that dose, not a potency): 76%
Beside the measured number, compound 4's estimate is 31 percentage points below it, and the stated range ends below it.
By their numbers in this assay, from the lowest: compound 2; then compound 3; then compound 4; then compound 1.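

In this assay, ((ethoxycarbonyl)carbonyl)amino in place of hydrogen three ring bonds from the ring atom that bears the first such group gives a modest step (a number 15 percentage points lower from compound 1 to compound 4 (beyond the scatter)), so this aromatic carbon takes a group of 8 heavy atoms with a measurable but limited loss. Substitution on the shared core therefore does not always bring a large step: methyl (a number 54 percentage points lower from compound 1 to compound 2 (beyond the scatter)) and methoxy (a number 35 percentage points lower from compound 1 to compound 3 (beyond the scatter)) each give a large one, while this larger entering group gives a modest one, and compound 1 still stays highest of the four. Nothing measured in hand explains the difference in size between these steps.

Whether the modest step belongs to the group itself or to this place on the ring stays open, as no compound shown carries methyl or methoxy at this place or a second ((ethoxycarbonyl)carbonyl)amino group elsewhere on the ring. A simple amine at this place, or a carboxylic acid in place of the ethyl ester of the entering group, would show how much of the entering group the read-out depends on.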